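Swapping isobutyl for cyclopentyl on a weak compound

The compounds below may be only part of what the source reports. "The series", "measured", "known", "first", "only" and "open" are said of these compounds alone.

Values in a functional assay on A2780 cells (Homo sapiens) for antiproliferative activity, read by MTT assay, with a stated time of 72 h; a higher number here means a weaker inhibitor, a lower number a stronger inhibitor:
- Compound 1 `CC(C)NC(=N)NC(=N)Nc1ccc(C(F)(F)F)cc1`: 3200 nM
- Compound 2 `CC(C)CNC(=N)NC(=N)Nc1ccc(C(F)(F)F)cc1`: 2100 nM
- Compound 3 `CC(C)CNC(=N)NC(=N)Nc1ccc(F)c(F)c1`: 6700 nM

Compound 3, at 6700 nM, has the highest number of the three, and its gaps to compound 1 and compound 2 both lie beyond the scatter. Compound 4 `N=C(NC(=N)NC1CCCC1)Nc1ccc(F)c(F)c1` differs from it in one group: cyclopentyl in place of isobutyl on an amine nitrogen. That is cyclopentyl in place of isobutyl on an amine nitrogen. Within the data shown here, only one measured step bears on this nitrogen: a 1.5-fold lower number from compound 1 to compound 2 (0.18 log units; within the scatter), which stays within the scatter. Among the measured compounds shown here, no measured step brings in a ring here, so this evidence is thin. No step beyond the scatter is therefore expected in this assay. The expected change is a 1.1-fold lower number from compound 3 to compound 4 (0.05 log units; within the scatter). For compound 4 the estimated value is 6000 nM, with an expected range of 2500 nM to 14000 nM.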

Compound 4, half-maximal inhibitory concentration: 9300 nM
Compound 4: the middle estimate sits 1.6-fold (0.19 log units) below what was measured, and the stated range covers the measured number.
By their numbers in this assay, from the lowest: compounds 2 and 1 (each within the scatter of the next); then compounds 3 and 4 (each within the scatter of the next).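

Putting cyclopentyl in place of isobutyl on this amine nitrogen gives a 1.4-fold higher number from compound 3 to compound 4 (0.14 log units; within the scatter) in this assay. Among these compounds, this is the first ring tested at this nitrogen, and the change stays within the scatter, so on the core of compound 3 the ring and the open isobutyl chain cannot be told apart. No measurement is available that speaks to what lies behind this result.

Still open, on these data alone, is whether a cyclohexyl ring, a phenyl ring or a longer chain would also leave the number in place at this nitrogen. Also open, as far as these compounds go, is whether cyclopentyl would behave the same way on the trifluoromethyl core of compound 2.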